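A Ringless Chain Replaces 4-Methoxyphenyl

The source may report more compounds than this note shows. Statements on the series, on what has been measured and on what is new or still open speak of the compounds shown alone.

In a functional assay on MCF7 cells (Homo sapiens) for inhibition, read by fluorescence, with a stated time of 72 h (a higher number here means a weaker inhibitor of growth, a lower number a stronger inhibitor of growth), compound 1 (`COc1ccc(Cn2cnc3c(Nc4cccc(Cl)c4)nc(N[C@H]4CC[C@H](N)CC4)nc32)cc1`) gives 4800 nM. Compound 2 (`CC(C)CCn1cnc2c(NCc3cccc(Cl)c3)nc(N[C@H]3CC[C@H](N)CC3)nc21`) gives 4700 nM, and compound 3 (`N[C@H]1CC[C@H](Nc2nc(Nc3ccc(O)cc3)c3ncn(C4CCCCC4)c3n2)CC1`) gives 9600 nM, so compound 1 stands within the scatter of both. Compound 4 (`CC(C)=CCC/C(C)=C/Cn1cnc2c(Nc3cccc(Cl)c3)nc(N[C@H]3CC[C@H](N)CC3)nc21`) remains unmeasured. It has 2,6-dimethylhepta-1,5-dien-1-yl in place of 4-methoxyphenyl on a saturated chain carbon bound to an aromatic nitrogen. For the measured compounds named here, no measured pair isolates a single change. Although it differs from compound 1 in more than one place, compound 2 also has a ringless chain there. Compound 2 gives 4700 nM, so little movement is expected in this assay, perhaps slightly toward a lower number. The expected change is a 1.4-fold lower number from compound 1 to compound 4 (0.14 log units; within the scatter). For compound 4, the estimated value is 3500 nM, with an expected range from 1200 nM to 10000 nM.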

Compound 4, concentration for 50% growth inhibition: 3600 nM
For compound 4 the middle estimate is 1.0-fold (0.01 log units) below the measured one; low and high end bracket the measured number.
By their numbers in this assay, from the lowest: compounds 4, 2, 1 and 3 (each within the scatter of the next, the first and the last beyond it).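

For the compounds shown here, this is the first step that changes only one place: in this assay, putting 2,6-dimethylhepta-1,5-dien-1-yl in place of 4-methoxyphenyl on a saturated chain carbon bound to an aromatic nitrogen gives a 1.3-fold lower number from compound 1 to compound 4 (0.12 log units; within the scatter). At this place, then, a ringless all-carbon chain and the 4-methoxyphenyl group leave the number within the scatter. Nothing available accounts for this result. Going by these compounds, it remains open whether a shorter chain, or a chain ending in an amine or a carboxylic acid, would also stay within the scatter of compound 1. On these data alone, whether the same swap behaves alike on the other compounds' cores is also open.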